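Cytotoxicity notes: cyclic amidine variant of compound 3

The compounds below may be only part of what the source reports. "The series", "measured", "known", "first", "only" and "open" are said of these compounds alone.

The series shares one core; the measured members are compound 1 `c1ccc(OCCCCCOc2ccc(-c3cc4cc(C5=NCCN5)ccc4o3)cc2)cc1`, compound 2 `N=C(N)c1ccc2oc(-c3ccc(OCCCCCCOc4ccccc4)cc3)cc2c1` and compound 3 `CC(C)NC(=N)c1ccc2oc(-c3ccc(OCCCCCCOc4ccccc4)cc3)cc2c1`. In an ADME assay on L6 cells (Rattus norvegicus) for cytotoxicity, read by resazurin assay, with a stated time of 70 h (a higher number here means a weaker inhibitor, a lower number a stronger inhibitor), compound 1 gives 900 nM, compound 2 gives 3300 nM and compound 3 gives 800 nM. Compound 3 holds the lowest of the three numbers, with compound 1 within the scatter of it and compound 2 well above it. Among the compounds with values here, the only single-point step measured is a 4.1-fold lower number from compound 2 to compound 3 (0.62 log units; beyond the scatter).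

Compound 4 `c1ccc(OCCCCCCOc2ccc(-c3cc4cc(C5=NCCN5)ccc4o3)cc2)cc1` has not yet been measured. It differs from compound 3 by a group of 5 heavy atoms (3 carbon, 2 nitrogen; one five-membered non-aromatic ring with 2 hetero atoms) in place of a group of 6 heavy atoms (4 carbon, 2 nitrogen; no ring), on an aromatic carbon. Within the data shown here, no measured step covers this exact change. Compound 1 carries the same entering group on a shorter chain and its value sits within the scatter of compound 3, while the step from compound 2 to compound 3 shows that substitution on the amidine nitrogen can move this assay. On this basis a step of a 1.2-fold higher number from compound 3 to compound 4 (0.07 log units; within the scatter) is expected, essentially none beyond the scatter. Compound 4 is therefore estimated at 950 nM in this assay, within a range from 400 nM to 2300 nM.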

Compound 4, half-maximal inhibitory concentration: 1500 nM
For compound 4 the middle estimate is 1.6-fold (0.20 log units) below the measured one; measured number inside the range.
By their numbers in this assay, from the lowest: compounds 3, 1 and 4 (each within the scatter of the next); then compound 2.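

In this assay, the five-membered non-aromatic ring group in place of the open isopropyl-bearing group on this aromatic carbon gives a 1.9-fold higher number from compound 3 to compound 4 (0.27 log units; within the scatter), so the two groups are not told apart here. Against the unsubstituted open group, the same ring group gives a 2.2-fold lower number from compound 2 to compound 4 (0.34 log units; beyond the scatter), a modest step in the same direction as a 4.1-fold lower number from compound 2 to compound 3 (0.62 log units; beyond the scatter). With the ring group in place, phenoxymethyl in place of phenoxy on the chain gives a 1.7-fold higher number from compound 1 to compound 4 (0.22 log units; within the scatter), so the chain change is not resolved either.

Nothing at hand explains these numbers. On these data alone, a six-membered ring in place of the five-membered one, or a longer chain with the ring group kept, remains open in this assay.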